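The source may hold more compounds than are shown below. What is called first, only, known or untested is meant among the compounds shown, and "the series" means these compounds.

Measured so far:
compound 1 `CN(C)Cc1cc2c(N)nc(-c3ccco3)nc2s1`: "not determined" (no result reported)
compound 2 `Nc1nc(-c2ccco2)nc2sc(CN3CC=CCC3)cc12`: < 3 mg/kg
compound 3 `Nc1nc(-c2ccco2)nc2sc(CN3CCC(=O)CC3)cc12`: "not determined" (no result reported)

These three compounds share a core and differ in the amine group carried on a saturated chain carbon. The test here is a functional assay on the whole organism (strain balb/c) with Mus musculus as the target, with a stated time of 30 min (a lower number here means that less compound is needed, a higher number that more compound is needed for the effect), in which compound 3 has the entry "not determined" (no result reported), so it has no single number to stand on. Compound 1 has the same kind of entry, "not determined" (no result reported), which leaves it no use as a yardstick. Compound 2 is recorded at < 3 mg/kg, and this is a limit, not a number.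

Compound 4 `Nc1nc(-c2ccco2)nc2sc(CN3CC=CC3)cc12` has not yet been measured. The change is a group of 5 heavy atoms (4 carbon, 1 nitrogen; one five-membered non-aromatic ring with 1 hetero atom) in place of a group of 7 heavy atoms (5 carbon, 1 nitrogen, 1 oxygen; one six-membered non-aromatic ring with 1 hetero atom), on a saturated chain carbon bound to an aromatic carbon. The 4-oxopiperidin-1-yl group leaves, and a group with one five-membered non-aromatic ring enters in its place.

Within the data shown here, no measured pair of compounds shows what a change of this kind does, and compound 3 offers no starting number, so no direction can be favoured. Among the measured compounds shown here, the only guide is compound 2 with its limit of < 3 mg/kg, so compound 4 is expected to fall within the usual scatter of that level in this assay, with no large step.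

For compound 4 the expected dose is estimated at 2 mg/kg, within an estimated range of 0.6 mg/kg to 6 mg/kg.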

Compound 4, dose for half-maximal effect: < 0.1 mg/kg
Compound 4: a limit, no number; the forecaster's own chance of this, stated with the estimate: 45%; middle value at least 20-fold (1.30 log units) away from the limit.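

Among these compounds, compound 2 and compound 4 are both recorded in this assay only as limits, not as numbers, so no step between them can be read. The compounds shown leave open whether the five-membered ring of compound 4 calls for a different dose than the six-membered ring of compound 2, and in which direction.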